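Chloro to Methoxy on a Shared Aminopyrimidine Core

The source may report more compounds than this note shows. Statements on the series, on what has been measured and on what is new or still open speak of the compounds shown alone.

Of the compounds shown here, three built on one shared core have been measured in a functional assay on U-87MG ATCC cells for antiproliferative activity against U-87 MG (Homo sapiens), read by MTT assay, with a stated time of 48 h, tested at 50 uM; a lower number here means a stronger effect, a higher number a weaker effect of the compound at the concentration tested. Compound 1 `COc1ccc(-c2nc(SCC(=O)c3sc(-c4ccccc4)nc3C)nc(N)c2C#N)cc1` gives 33.8%. Compound 2 `Cc1nc(-c2ccccc2)sc1C(=O)CSc1nc(N)c(C#N)c(-c2ccc(Cl)cc2)n1` gives 44.3%. Compound 3 `Cc1nc(-c2ccc(Cl)cc2)sc1C(=O)CSc1nc(N)c(C#N)c(-c2ccc(Cl)cc2)n1` gives 15.5%, the lowest of the three, and its steps to both of the others lie beyond the scatter.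

Two single changes tie the measured set together. From compound 2 to compound 1 the change is methoxy in place of chloro on an aromatic carbon, and the step it made was a number 10.5 percentage points lower from compound 2 to compound 1 (beyond the scatter). From compound 2 to compound 3 the step was a number 28.8 percentage points lower from compound 2 to compound 3 (beyond the scatter).

Compound 4 `COc1ccc(-c2nc(SCC(=O)c3sc(-c4ccc(Cl)cc4)nc3C)nc(N)c2C#N)cc1` has not yet been measured. It differs from compound 3 by methoxy in place of chloro on an aromatic carbon, the same change that leads from compound 2 to compound 1; among the compounds shown this change occurs two times in all, and the place of the change is described in the same words both times. The two cores on which it is made differ from one another by chloro in place of hydrogen on an aromatic carbon.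

Resting on the measured pair, the step in this assay from compound 3 to compound 4 is expected to be a number 7.5 percentage points lower from compound 3 to compound 4 (within the scatter). That expectation rests on the earlier step, a number 10.5 percentage points lower from compound 2 to compound 1 (beyond the scatter), tempered by the already low starting value of compound 3, which leaves less room for a fall of the same size. Compound 4 is therefore estimated at 8%, with a likely range from 0% to 22%.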

Compound 4, a percentage reported as activity, at one concentration (the size of the read-out at that concentration, not a potency): 17.8%
Compound 4: the middle estimate sits 9.8 percentage points below what was measured, and the stated range covers the measured number.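

In this assay the change from 4-chlorophenyl to 4-methoxyphenyl gave a number 2.3 percentage points higher from compound 3 to compound 4 (within the scatter), and the two readings of this change do not differ by more than repeated measurement allows: the same change on two cores in this assay, a number 10.5 percentage points lower (beyond the scatter) from compound 2 to compound 1 and a number 2.3 percentage points higher (within the scatter) from compound 3 to compound 4, 12.8 percentage points apart, within the scatter of two such steps. The other single change, chloro in place of hydrogen on an aromatic carbon, gave a number 16 percentage points lower from compound 1 to compound 4 (beyond the scatter), and it too agrees with its earlier counterpart: the same change on two cores in this assay, a number 28.8 percentage points lower (beyond the scatter) from compound 2 to compound 3 and a number 16 percentage points lower (beyond the scatter) from compound 1 to compound 4, 12.8 percentage points apart, within the scatter of two such steps. Both changes are therefore compatible with carrying over between these two cores, but that rests on one pair of cores, the methoxy step lies beyond the scatter on one core and within it on the other, and nothing here shows that either step has one fixed size or would hold on a further core.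

The compounds shown leave open how an amine, a carboxylic acid or a longer chain such as ethoxy would read at the same place on the aromatic ring, where only hydrogen, chloro and methoxy appear. They also leave open what follows when the nitrile or the amino group of the shared core gives way to another group, since both stay the same throughout.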